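The source may hold more compounds than are shown below. What is called first, only, known or untested is meant among the compounds shown, and "the series" means these compounds.

Measured compounds:
- compound 1 `CCC(=O)c1cc(-c2ccc(Cl)cc2)[nH]c1C` gives 900 nM
- compound 2 `Cc1ccc(-c2ccc(Cl)cc2)n1-c1ccc(S(N)(=O)=O)cc1` gives 6100 nM
- compound 3 `CCC(=O)c1cc(-c2ccc(Cl)cc2)n(-c2ccc(S(C)(=O)=O)cc2)c1C` gives 4800 nM

In a physicochemical assay for solubility, read by HPLC, in phosphate buffer, measured as kinetic solubility, at pH 7.4 (on this read-out lower numbers stand for lower solubility and higher numbers for higher solubility), compound 2 stands highest of the three numbers shown. Its nearest neighbour is compound 3, whose value lies within the scatter of compound 2; its furthest is compound 1, whose lower value lies beyond the scatter. Compound 4 `CC(=O)c1cc(-c2ccc(Cl)cc2)n(-c2ccc(S(N)(=O)=O)cc2)c1C` has not yet been measured. It differs from compound 2 by one change: acetyl in place of hydrogen on an aromatic carbon. Within the data shown here, no pair of measured compounds shows this same change, so no measured step guides the expectation. Compound 3, which carries a propanoyl group on the same core, sits within the scatter of compound 2, and this weighs toward a small effect. The expected step is a 1.4-fold lower number from compound 2 to compound 4 (0.13 log units; within the scatter), within the scatter. Compound 4 is expected to give about 4500 nM, with a range from 1500 nM to 13000 nM.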

Compound 4, solubility: 2700 nM
The estimate for compound 4 lay 1.7-fold (0.22 log units) above the measured number; the measured number falls inside the stated range.
By their numbers in this assay, from the lowest: compound 1; then compounds 4, 3 and 2 (each within the scatter of the next, the first and the last beyond it).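

Acetyl in place of hydrogen on the aromatic carbon two ring bonds from the ring nitrogen brings a 2.3-fold lower number from compound 2 to compound 4 (0.35 log units; beyond the scatter) in this assay. Among these compounds, this is the first step between compounds differing in one place, so this position now has a direct reading: the change lowers the number modestly, but beyond the scatter. Nothing available accounts for the size of this step.

On these data alone, whether an amine, a carboxylic acid or a longer chain on this carbon would lower the number as well remains open. So does whether acetyl would give a similar step on another core.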